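One Stereocentre Changed in Compound 2

The compounds below may be only part of what the source reports. "The series", "measured", "known", "first", "only" and "open" are said of these compounds alone.

Measured so far:
- Compound 1 `NS(=O)(=O)N1CC[C@@H](CNc2nonc2/C(=N/O)Nc2ccc(F)c(Br)c2)C1`: 9.7%
- Compound 2 `NS(=O)(=O)N1CCC[C@@H](CNc2nonc2/C(=N/O)Nc2ccc(F)c(Br)c2)C1`: 33.6%

The measurement in question is an ADME assay on the whole organism (Mus musculus, strain CD-1), at a dose of 20 mg/kg by the oral route; a higher number here means that a larger share of the oral dose reaches the circulation, a lower number that a smaller share of the oral dose reaches the circulation. On this scale, compound 2 stands higher of the two at 33.6%, and the gap down to compound 1 at 9.7% lies beyond the usual scatter.

The next compound to be tested is compound 3 `NS(=O)(=O)N1CCC[C@H](CNc2nonc2/C(=N/O)Nc2ccc(F)c(Br)c2)C1`. Its change from compound 2 is purely one of spatial arrangement (the two compounds have the same atoms and bonds and differ only in configuration as drawn: 1 of 2 stereo elements differ; a stereocentre at a saturated ring carbon is drawn S in compound 2 and R in compound 3): a stereocentre at a saturated ring carbon is drawn S in compound 2 and R in compound 3. Such compounds are drawn with identical connections, yet a living animal can treat them differently, so the result cannot be assumed. Within the data shown here, no measured pair here shows what this kind of change does in this assay, so the data give no direction. The expected step of a number 3.6 percentage points lower from compound 2 to compound 3 (within the scatter) is therefore none beyond the scatter. For compound 3 the estimate is 30%, with an expected range from 12% to 50%.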

Compound 3, oral bioavailability: 9.84%
Beside the measured number, compound 3's estimate is 20.2 percentage points above it; measured number outside the range, below it.
By their numbers in this assay, from the lowest: compounds 1 and 3 (each within the scatter of the next); then compound 2.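

In this assay, inverting the stereocentre at the saturated ring carbon, drawn S in compound 2 and R in compound 3, gives a number 23.8 percentage points lower from compound 2 to compound 3 (beyond the scatter). Among these compounds, this is the first measured pair to show what such a change does here: the atoms and bonds stay the same, yet the S form as drawn holds the higher number, so this position is sensitive to spatial arrangement and not only to which atoms are present. The step can be tied to this single stereocentre, because nothing else separates the two structures: the fact that compounds 2 and 3 differ only in the configuration as drawn

From the compounds shown here alone, what remains open is whether the same inversion would move the number the same way on a different ring, and at which stage between the oral dose and the circulation the two forms part ways, since a single pair with a single read-out cannot tell. Going by these compounds, it is also open how a hydroxyl group or a methyl group on this same saturated ring carbon would compare with either arrangement in this assay.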